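A Benzyl Swap on a Diamino Core Measured in One Cell Assay

This account rests on a few compounds, and the source may have more. Where it says the series, first, only, none or still open, it means among the compounds named here.

Measured compounds:
compound 1 `Nc1cc(N)c2nc(-c3ccccc3)c(NCc3ccc(Cl)c(Cl)c3)nc2c1`: 7590 nM
compound 2 `CCOC(=O)[C@H](CCC(=O)O)NC(=O)c1ccc(Oc2nc3cc(N)cc(N)c3nc2-c2ccccc2)cc1`: < 100000 nM

Both compounds were tested in a functional assay on MDA-MB-435 cells (Homo sapiens) for inhibition, read by sulforhodamine B assay, with a stated time of 48 h; a higher number here means a weaker inhibitor of growth, a lower number a stronger inhibitor of growth. Within the data shown here, compound 1 supplies the only actual number in this assay. The result for compound 2 is a limit of the assay rather than a number, as stated in the limit of < 100000 nM in this assay, at which 1 of the 2 values shown sits; it says nothing more about how compound 2 compares.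

Compound 3 `COc1ccc(CNc2nc3cc(N)cc(N)c3nc2-c2ccccc2)cc1` has not yet been measured. It differs from compound 1 in a single place: 4-methoxyphenyl in place of 3,4-dichlorophenyl on a saturated chain carbon bound to a nitrogen on an aromatic ring. Among the measured compounds shown here, no measured pair shows this particular change, so any expectation rests on compound 1 alone and on the change itself.

The expected step from compound 1 to compound 3 is a 2.0-fold higher number from compound 1 to compound 3 (0.30 log units; within the scatter), a move toward weaker growth inhibition, modest in size but probably beyond the usual scatter. Compound 3 is therefore estimated at 15000 nM in this assay, with a plausible range from 4000 nM to 60000 nM.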

Compound 3, concentration for total growth inhibition: 21900 nM
Compound 3: the middle estimate sits 1.5-fold (0.16 log units) below what was measured; low and high end bracket the measured number.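

Among these compounds, replacing 3,4-dichlorophenyl with 4-methoxyphenyl gives a 2.9-fold higher number from compound 1 to compound 3 (0.46 log units; beyond the scatter) in this assay, the first measured change at this place on the saturated chain carbon bound to a nitrogen on an aromatic ring. The group at this place therefore affects the read-out, even though both groups hold 8 heavy atoms and one six-membered aromatic ring of carbon only, so these counts alone do not fix the result. No measured property shown here accounts for the shift.

With two things changing at once, this single step cannot separate losing the two chlorines from gaining the methoxy group. A 4-chlorophenyl or an unsubstituted phenyl at the same place would help to separate them, and a longer chain between the nitrogen and the ring remains an open variation.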